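Replacing 4-fluorophenyl with (2-chlorophenyl)carbonyl at the assay limit

This account rests on a few compounds, and the source may have more. Where it says the series, first, only, none or still open, it means among the compounds named here.

Compound 1 `Cc1cccc(NNC(=O)c2ccc(NS(=O)(=O)c3cnc(O)nc3O)cc2)c1` gives > 20000 nM in a functional assay on OVCAR-3 cells (Homo sapiens) for antiproliferative activity, read by MTT assay, with a stated time of 24 h (a higher number here means a weaker inhibitor, a lower number a stronger inhibitor), which is a limit of the assay and not a true number. Compound 2 `O=C(NNc1ccc(F)cc1)c1ccc(NS(=O)(=O)c2cnc(O)nc2O)cc1` gives > 20000 nM in this assay, which is also only a limit. Compound 2 therefore has no exact value, and the picture so far is the limit of > 20000 nM in this assay, at which 2 of the 2 values shown sit.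

The next compound, compound 3 `O=C(NNC(=O)c1ccccc1Cl)c1ccc(NS(=O)(=O)c2cnc(O)nc2O)cc1`, changes compound 2 on an amine nitrogen: (2-chlorophenyl)carbonyl in place of 4-fluorophenyl on an amine nitrogen. Within the data shown here, only one measured step bears on this change, namely a step that the two limits leave unreadable from compound 1 to compound 2. That step has no readable size, so it offers no size or direction to carry over.

In this assay, the expected result is therefore no change beyond the scatter, and the estimated step is a number no higher from compound 2 to compound 3 (the limit leaves the size open). For compound 3 the estimate is 20000 nM, with an expected range of 8000 nM to 40000 nM.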

Compound 3, half-maximal inhibitory concentration: 5220 nM
For compound 3 the middle estimate is 3.8-fold (0.58 log units) above the measured one; the whole stated range lies above it.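

Compounds 1 and 2, which carry a phenyl ring directly on this amine nitrogen, showed nothing readable, and the step between them cannot be read. Placing (2-chlorophenyl)carbonyl on the same nitrogen shows that a change here can move the result in this assay, with an at least 3.8-fold lower number from compound 2 to compound 3 (0.58 log units; beyond the scatter) and an at least 3.8-fold lower number from compound 1 to compound 3 (0.58 log units; beyond the scatter). Both steps start from a limit of the assay, so their true sizes stay unknown, and compound 3 alone has an exact value: the limit of > 20000 nM in this assay, at which 2 of the 3 values shown sit.

The change brings in a carbonyl and a chlorine at once, so the compounds shown do not tell which of them matters, or whether both do. A phenylcarbonyl group without the chlorine, or a small acetyl group on this nitrogen, would help to separate the two.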